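Aryl amide variation on a thiazole acylurea-hydrazone series

The source may report more compounds than this note shows. Statements on the series, on what has been measured and on what is new or still open speak of the compounds shown alone.

Measured so far:
compound 1 `CN(C(=O)NC(=O)c1cccc(C(F)(F)F)c1)c1nc(C(F)(F)F)c(C(=O)N/N=C/c2ccccc2C(F)(F)F)s1` — 12.1 ug/mL
compound 2 `CN(C(=O)NC(=O)c1ccc(Cl)cc1Cl)c1nc(C(F)(F)F)c(C(=O)N/N=C/c2ccccc2C(F)(F)F)s1` — 15.3 ug/mL

In a functional assay on A549 cells (Homo sapiens) for inhibition, read by MTT assay, with a stated time of 72 h (on this read-out lower numbers stand for stronger inhibition and higher numbers for weaker inhibition), compound 1 gives 12.1 ug/mL and compound 2 gives 15.3 ug/mL. Compound 2 has the highest of the two numbers, but a 1.3-fold higher number from compound 1 to compound 2 (0.10 log units; within the scatter) keeps the two within the scatter, so no order between them can be read.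

Compound 3 `CN(C(=O)NC(=O)c1ccccc1F)c1nc(C(F)(F)F)c(C(=O)N/N=C/c2ccccc2C(F)(F)F)s1` is not yet measured. It differs from compound 2 by 2-fluorophenyl in place of 2,4-dichlorophenyl on a carbonyl carbon. Going by the values given here, the one step that bears on this position is a 1.3-fold higher number from compound 1 to compound 2 (0.10 log units; within the scatter), a swap of the aryl group on the same carbonyl carbon that left the number essentially unchanged. On that single precedent the expectation for compound 3 is a step of a 1.1-fold lower number from compound 2 to compound 3 (0.04 log units; within the scatter) in this assay, that is, no movement beyond the scatter in either direction. Compound 3 is therefore estimated at 14 ug/mL, with a range of 7 ug/mL to 28 ug/mL.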

Compound 3, half-maximal inhibitory concentration: 6.32 ug/mL
For compound 3 the middle estimate is 2.2-fold (0.35 log units) above the measured one; measured number outside the range, below it.
By their numbers in this assay, from the lowest: compounds 3, 1 and 2 (each within the scatter of the next, the first and the last beyond it).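

In this assay the aryl group on this carbonyl carbon can move the number beyond the scatter: 2-fluorophenyl in place of 2,4-dichlorophenyl gives a 2.4-fold lower number from compound 2 to compound 3 (0.38 log units; beyond the scatter), the only step of that kind among these compounds. The replacement of 3-(trifluoromethyl)phenyl by 2-fluorophenyl stays inside the scatter at a 1.9-fold lower number from compound 1 to compound 3 (0.28 log units; within the scatter), so compound 3 separates from compound 2 but not from compound 1, and compound 1 in turn does not separate from compound 2. No measurement bears on why the step occurs.

Open, from the compounds shown here alone, is how an unsubstituted phenyl, or a phenyl carrying an amine or a carboxylic acid, would read on the same carbonyl carbon. Also open, going by these compounds, is whether the step between these two aryl groups would persist with a different group on the hydrazone end.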